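The source may hold more compounds than are shown below. What is called first, only, known or untested is meant among the compounds shown, and "the series" means these compounds.

Compound 1, with the structure `CC(C(=O)N1CCN(c2ccccc2)CC1)N1C(=O)CCC1=O`, is the starting point. In a functional assay on the whole organism (strain Swiss) with Mus musculus as the target, in the maximal electroshock model, with a stated time of 2 h, at a dose of 300 mg/kg by the intraperitoneal route (a higher number here means a stronger effect of the compound at the dose given, a lower number a weaker effect), compound 1 gives 0%. Two measured compounds differ from it in one place. Compound 2 `CC(C(=O)N1CCN(c2ccccc2F)CC1)N1C(=O)CCC1=O` carries fluoro in place of hydrogen on an aromatic carbon and gives 25%, so that a number 25 percentage points higher from compound 1 to compound 2 (beyond the scatter). Compound 3 `CC(C(=O)N1CCN(c2ccccc2Cl)CC1)N1C(=O)CCC1=O` carries chloro in place of hydrogen on an aromatic carbon and gives 0%, so that no change at the digits printed from compound 1 to compound 3 (within the scatter). Between these two, a number 25 percentage points lower from compound 2 to compound 3 (beyond the scatter). Compound 1 thus stands level with compound 3 at the bottom of the three numbers, and only compound 2 lies higher, beyond the scatter.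

Compound 4 `CC(C(=O)N1CCN(c2cccc(C(F)(F)F)c2)CC1)N1C(=O)CCC1=O` is not yet measured. It differs from compound 1 as follows: trifluoromethyl in place of hydrogen on an aromatic carbon. Among the compounds with values here, no measured step puts a trifluoromethyl group onto the ring, and none changes the ring at this place, so the steps to compound 2 and compound 3 bear on it only loosely. They show that a single small halogen at one place on the ring gave at most a modest rise, and in one case none. The step of a number 10 percentage points higher from compound 1 to compound 4 (within the scatter) is therefore expected to be small or absent, in the direction of a rise if any. Compound 4 is estimated at 10%, within a range from 0% to 40%.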

Compound 4, a percentage reported as activity, at one dose (the size of the read-out at that dose, not a potency): 100%
Beside the measured number, compound 4's estimate is 90 percentage points below it; measured number above the stated range.
By their numbers in this assay, from the lowest: compounds 1 and 3 (each within the scatter of the next); then compound 2; then compound 4.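

On the aromatic ring of the core, a trifluoromethyl group meta to a large group produces a far bigger change than any seen so far: in this assay, the result is a number 100 percentage points higher from compound 1 to compound 4 (beyond the scatter). Within the data shown here, the earlier ring changes gave only a modest rise, a number 25 percentage points higher from compound 1 to compound 2 (beyond the scatter), or no change at the digits printed from compound 1 to compound 3 (within the scatter), so this is the first sign that a single change on this ring can take the read-out from the bottom of the series to a large effect at the dose given. No measurement shown here explains the size of this step, and its cause remains unknown.

The compounds shown leave open whether the rise belongs to the trifluoromethyl group itself or to the place it occupies, a question that a fluoro, a chloro, a methyl group or a nitrile at that same place could help to settle. Also open, on these data alone, is how compound 4 would behave at lower doses, as a read-out at one dose shows the size of the effect there and not the potency.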